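Phenyl in place of a carbamate-bearing chain on the sulfonyl

The source may report more compounds than this note shows. Statements on the series, on what has been measured and on what is new or still open speak of the compounds shown alone.

Compound 1, `CC(C)S(=O)(=O)NC(=O)c1ccc(Nc2nc(NC3(c4ccc(Cl)cc4)CC3)nc(OCC(F)(F)F)n2)cc1`, gives 96% in an ADME assay on microsomes from liver (Rattus norvegicus) for metabolic stability, with a stated time of 10 min; a lower number here means that less of the compound is left, a higher number that more of the compound is left.
Compound 2, `CC(C)NCCS(=O)(=O)NC(=O)c1ccc(Nc2nc(NC3(c4ccc(Cl)cc4)CC3)nc(OCC(F)(F)F)n2)cc1`, gives 100% in this assay.
Compound 3, `CC(C)(C)OC(=O)NCCS(=O)(=O)NC(=O)c1ccc(Nc2nc(NC3(c4ccc(Cl)cc4)CC3)nc(OCC(F)(F)F)n2)cc1`, gives 93% in this assay.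
Compound 4, `O=C(NS(=O)(=O)c1ccccc1)c1ccc(Nc2nc(NC3(c4ccc(Cl)cc4)CC3)nc(OCC(F)(F)F)n2)cc1`, has not yet been measured in this assay.

All three measured compounds share the same core and differ only in the group attached to the sulfonyl sulfur of the acylsulfonamide. Compound 3 has the lowest of the three numbers, but its distance to the others is small: a number 3 percentage points lower from compound 1 to compound 3 (within the scatter) and a number 7 percentage points lower from compound 2 to compound 3 (within the scatter). Both steps lie within the scatter, so the three compounds cannot be ordered on these data; all of them are left largely intact after the stated time.

The next step changes the same position: phenyl in place of 2-((tert-butoxycarbonyl)amino)ethyl on a sulfonyl sulfur. The measured steps that bear on this position are a number 4 percentage points higher from compound 1 to compound 2 (within the scatter) and a number 3 percentage points lower from compound 1 to compound 3 (within the scatter), together with the change on the amine nitrogen of that chain, a number 7 percentage points lower from compound 2 to compound 3 (within the scatter). Each of them left the number essentially unchanged. Among the measured compounds shown here, no measured step covers an aromatic group on the sulfonyl sulfur, so the expectation rests on this pattern alone. Compound 4 is therefore expected to stay near the high level seen so far, with an estimated step of a number 1 percentage points higher from compound 3 to compound 4 (within the scatter), that is, none beyond the scatter. The estimate for compound 4 is 94%, between 80% and 100%.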

Compound 4, percent of the compound remaining: 100%
Compound 4: the middle estimate sits 6 percentage points below what was measured; measured number inside the range.
By their numbers in this assay, from the lowest: compounds 3, 1, 2 and 4 (each within the scatter of the next).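

Among the compounds shown here, the phenyl group of compound 4 is the first aromatic group on the sulfonyl sulfur, and in this assay it behaves like the open chains: a number 7 percentage points higher from compound 3 to compound 4 (within the scatter), no change at the digits printed from compound 2 to compound 4 (within the scatter) and a number 4 percentage points higher from compound 1 to compound 4 (within the scatter). Replacing a chain with a ring therefore leaves the amount of compound remaining unchanged within the scatter, so isopropyl, 2-(isopropylamino)ethyl, 2-((tert-butoxycarbonyl)amino)ethyl and phenyl cannot be told apart in this assay. Nothing shown explains why the number stays the same across these different groups at this position.

Still open, on these data alone, is whether this holds for a phenyl ring carrying an amine or a carboxylic acid, or for a longer alkyl chain on the sulfonyl sulfur. All four compounds also share the same core and one stated incubation time, so the data cannot show how these groups would compare on a different core or after a longer incubation.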